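The compounds below may be only part of what the source reports. "The series", "measured", "known", "first", "only" and "open" are said of these compounds alone.

Compound 1 `CCc1ccc(NC(=O)CSc2nc(Nc3ccccc3)c3ccccc3n2)cc1`: 9910 nM
Compound 2 `C=CC(=O)Nc1cccc(NC(=O)CSc2nc(Nc3ccccc3Cl)c3ccccc3n2)c1`: 10000 nM

Of the compounds shown here, two from this series have been measured in a functional assay on NCI-H1975 cells (Homo sapiens) for inhibition, read by MTT assay, with a stated time of 72 h; a higher number here means a weaker inhibitor, a lower number a stronger inhibitor. Compound 1 gives 9910 nM, and compound 2 gives 10000 nM. The two numbers sit within the usual scatter of each other, so compound 2 cannot be set apart from compound 1 on these data: both are weak inhibitors in this assay, and neither value can be called higher or lower in any meaningful sense.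

Compound 3 `C=CC(=O)Nc1cccc(NC(=O)CSc2nc(Nc3cc(OC)c(OC)c(OC)c3)c3ccccc3n2)c1` has not yet been measured. It differs from compound 2 in one place: 3,4,5-trimethoxyphenyl in place of 2-chlorophenyl on a nitrogen on an aromatic ring. Among the measured compounds shown here, no step between measured compounds is available to show what such a change does in this assay, and the two measured values give no trend to lean on.

With nothing in the data pointing either way, the expectation for compound 3 is a step of about a 1.1-fold lower number from compound 2 to compound 3 (0.02 log units; within the scatter), that is, no change beyond the scatter. Compound 3 is therefore estimated at 9500 nM, within a range from 3000 nM to 30000 nM.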

Compound 3, half-maximal inhibitory concentration: > 50000 nM
Compound 3 ended at the assay's limit; the forecaster's own chance of this, stated with the estimate: 35%; at least 5.2-fold (0.72 log units) between middle value and limit.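

In this assay, among the compounds shown here, the exchange of one substituted phenyl group for another gives an at least 5.0-fold higher number from compound 2 to compound 3 (0.69 log units; beyond the scatter), the first change in a single place that can be read. The earlier pair differed in more than one place and stood within the scatter of each other, so it could not show whether the group at this place affects the read-out; this step shows that it does, and that this replacement goes towards weaker inhibition. The size of the step is only a lower bound, as compound 3 reached a limit of the assay rather than giving a number: the limit of > 50000 nM in this assay, at which 1 of the 3 values shown sits.

What the compounds shown leave open is whether the loss follows from the arrival of the trimethoxy pattern, from the departure of the chlorine, or from both, and a single methoxy group or a lone chlorine at another place on the phenyl ring would bear on that. Whether an amine such as morpholine on that ring would be tolerated at this place also remains unanswered.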